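Removing the hydroxy of compound 2 for a phenyl

A few compounds are considered here, and "the series" means these few. Any claim that something is new, unique, unknown or untested is made for them only; others in the source may bear on it.

Compound 2 `CCOC(=O)C(=O)Nc1ccccc(O)c1=O` stands lowest of the two numbers in a functional assay on the whole organism (strain Sprague-Dawley CD) for inhibition, with Rattus norvegicus as the target, read by paw edema, at a dose of 100 mg/kg by the oral route (a higher number here means a stronger effect of the compound at the dose given, a lower number a weaker effect), where compound 2 gives 0%. Its nearest neighbour is compound 1 `CCOC(=O)C(=O)Nc1cccccc1=O`, which in this assay gives 91%. Among the compounds with values here, the only measured step, a number 91 percentage points lower from compound 1 to compound 2 (beyond the scatter), is a large loss beyond the scatter. Compound 3 `CCOC(=O)C(=O)Nc1ccccc(-c2ccccc2)c1=O` differs from compound 2 as follows: phenyl in place of hydroxy on an aromatic carbon. Within the data shown here, this step bears on the measured one in reverse, in that the hydroxy leaves again, but the phenyl that enters has no counterpart among the measured compounds, so the size of its own effect is unknown. On the reasoning that compound 1 without the hydroxy gives 91%, a step back upward beyond the scatter is expected for compound 3, estimated as a number 50 percentage points higher from compound 2 to compound 3 (beyond the scatter). Compound 3 is thus expected to give about 50% in this assay, within a range of 10% to 90%.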

Compound 3, a percentage reported as inhibition, in the whole organism at one dose (the size of the read-out at that dose, not a potency): 0%
The estimate for compound 3 lay 50 percentage points above the measured number; the whole stated range lies above it.
By their numbers in this assay, from the lowest: compounds 2 and 3 (each within the scatter of the next); then compound 1.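

In this assay, phenyl in place of hydroxy on the aromatic carbon two ring bonds from the ring atom that bears a group of 8 heavy atoms gives no change at the digits printed from compound 2 to compound 3 (within the scatter), so the loss seen with hydroxy does not return to the level of compound 1 once hydroxy leaves. Phenyl in place of hydrogen at that place gives a number 91 percentage points lower from compound 1 to compound 3 (beyond the scatter), so the loss now holds for two different groups, and among these three compounds only compound 1, with hydrogen there, keeps the effect at this dose. No available evidence bears on the reason for this loss with either group.

Still open, on these data alone, is whether a methyl, a fluorine or an amine at this place would also lose the effect, or whether any group there would. Also open, as far as these compounds go, is how the same phenyl or hydroxy would read on another ring carbon of the core.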